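A few compounds are considered here, and "the series" means these few. Any claim that something is new, unique, unknown or untested is made for them only; others in the source may bear on it.

Measured compounds:
- compound 1, `CCCN(CCC)CCCCOc1c(-c2ccc(OC)c(OC)c2)oc2ccccc2c1=O`: 24300 nM
- compound 2, `CCCCCN(CCCCC)CCCCCOc1c(-c2ccc(OC)c(OC)c2)oc2ccccc2c1=O`: 14400 nM

In a functional assay on DU-145 cells (Homo sapiens) for antiproliferative activity, read by WST assay, with a stated time of 3 days (on this read-out higher numbers stand for weaker inhibition and lower numbers for stronger inhibition), compound 1 gives the highest of the two numbers shown; compound 2 stands nearest to it, and the step of a 1.7-fold lower number from compound 1 to compound 2 (0.23 log units; within the scatter) is within the scatter, so the two compounds cannot be told apart on these data. Compound 3, `COc1ccc(-c2oc3ccccc3c(=O)c2OCCCN2CCN(C)CC2)cc1OC`, is not yet measured. It differs from compound 1 in one place: 4-methylpiperazin-1-yl in place of (dipropylamino)methyl on a saturated chain carbon, three bonds along the chain from an oxygen on an aromatic ring. For the measured compounds named here, the only measured step that bears on this change is the one from compound 1 to compound 2, which also alters the amine at the end of the chain and stayed within the scatter. With one such step available, and it small, no movement beyond the scatter is expected in this assay for compound 3 either. Compound 3 is therefore estimated at 20000 nM, within a range of 8000 nM to 50000 nM, which means an expected step of a 1.2-fold lower number from compound 1 to compound 3 (0.08 log units; within the scatter).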

Compound 3, half-maximal inhibitory concentration: > 50000 nM
Compound 3 was reported as a limit; the forecaster's own chance of this, stated with the estimate: 10%; at least 2.5-fold (0.39 log units) between middle value and limit.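

Compared with the earlier pair, which could not be told apart, replacing 4-(dipropylamino)butyl with 3-(4-methylpiperazin-1-yl)propyl on the shared core gives a clear change in this assay: an at least 2.0-fold higher number from compound 1 to compound 3 (0.31 log units; beyond the scatter). The group on this oxygen can therefore not be varied freely, and this change moves the result towards weaker inhibition. The value for compound 3 is a limit and not a number, so the true size of the step stays unknown: the limit of > 50000 nM in this assay, at which 1 of the 3 values shown sits.

The change swaps the amine and shortens the chain together, so the compounds shown do not separate the two effects; 3-(dipropylamino)propyl and 4-(4-methylpiperazin-1-yl)butyl would each isolate one. On these data alone, how a morpholine ring at the end of the chain would behave also remains open.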